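Notes on the cyano-to-iodo step in one series

The source may hold more compounds than are shown below. What is called first, only, known or untested is meant among the compounds shown, and "the series" means these compounds.

Measured so far in a functional assay on cells for agonist activity at Free fatty acid receptor 1 (Homo sapiens), read by FLIPR and calcium flux; on this read-out lower numbers stand for an effect already at smaller amounts and higher numbers for an effect only at larger amounts of compound:
compound 1 `CC#C[C@@H](Cc1nnn[nH]1)c1ccc(OCc2ccc3sc(F)c(-c4ccc(OCCOC)cc4C)c3c2)cc1`, which gives 18 nM
compound 2 `CC#C[C@@H](Cc1nnn[nH]1)c1ccc(OCc2ccc3sc(C#N)c(-c4ccccc4C)c3c2)cc1`, which gives 16 nM
compound 3 `CC#C[C@@H](Cc1nnn[nH]1)c1ccc(OCc2ccc3scc(-c4cccnc4C)c3c2)cc1`, which gives 88 nM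

Compound 2 has the lowest number of the three in this assay. Compound 1 sits within the scatter of compound 2, so the two cannot be told apart on these numbers. Compound 3 lies beyond the scatter above compound 2, and it differs from compound 2 in more than one place, so the gap is noted only as a gap.

The next compound, compound 4 `CC#C[C@@H](Cc1nnn[nH]1)c1ccc(OCc2ccc3sc(I)c(-c4ccccc4C)c3c2)cc1`, differs from compound 2 in one place: iodo in place of cyano on an aromatic carbon. Among the measured compounds shown here, no pair of measured compounds shows what this change does on its own. Compound 1 and compound 2 carry different single groups at this position and give numbers within the scatter of each other, which is the only hint available.

Compound 4 is expected to stay near compound 2, the step of a 1.6-fold higher number from compound 2 to compound 4 (0.19 log units; within the scatter) being within or only just beyond the scatter. The estimate for compound 4 is 25 nM, with a range from 8 nM to 80 nM.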

Compound 4, half-maximal effective concentration: 28 nM
Estimate against measurement, compound 4: 1.1-fold (0.05 log units) below; the measured number falls inside the stated range.
By their numbers in this assay, from the lowest: compounds 2, 1 and 4 (each within the scatter of the next); then compound 3.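

In this assay, iodo in place of cyano on the aromatic carbon next to the ring sulfur gives a 1.8-fold higher number from compound 2 to compound 4 (0.24 log units; within the scatter), which puts a figure on this single change at this position. The cyano group, with its triple bond and its hydrogen-bond acceptor, gives way here to a single iodine atom with no hydrogen-bond acceptor, and the step stays within the scatter, so in this pair neither feature is required to keep the number in this range. No measured property is available to account for this result.

Still open, on these data alone, is whether an amine or a carboxylic acid on the same carbon would also stay within the scatter of compound 2. As far as these compounds go, it is also open whether the same change gives a similar step when the 2-methylphenyl group is replaced.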